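Stereochemical Inversion on the Fluorocyclopropyl Amide

The compounds below may be only part of what the source reports. "The series", "measured", "known", "first", "only" and "open" are said of these compounds alone.

Compound 1, `CC(C)C(=O)N1CC2CC(C1)N2`: 45%
Compound 2, `O=C(C1CCC1)N1CC2CC(C1)N2`: 80%
Compound 3, `O=C([C@@H]1C[C@@H]1F)N1CC2CC(C1)N2`: 120%

Three amides of the shared core have been measured in an assay on CHO cells for agonist activity at Neuronal acetylcholine receptor; alpha3/alpha6/beta2/beta3 (Homo sapiens), read by FLIPR and calcium flux; on this read-out higher numbers stand for larger maximal responses and lower numbers for smaller maximal responses. Compound 3 stands highest of the three: the step of a number 40 percentage points higher from compound 2 to compound 3 (beyond the scatter) is beyond the scatter, and so is the step of a number 75 percentage points higher from compound 1 to compound 3 (beyond the scatter). The step of a number 35 percentage points higher from compound 1 to compound 2 (beyond the scatter) shows that exchanging the group on the carbonyl carbon alone moves the maximal response a long way.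

Compound 4, `O=C([C@@H]1C[C@H]1F)N1CC2CC(C1)N2`, differs from compound 3 only in this respect: the two compounds have the same atoms and bonds; at least one stereo element is drawn with a configuration in one of them and without one in the other: 1 of 4 stereo elements differ; a stereocentre at a saturated ring carbon is drawn S in compound 3 and R in compound 4. None of the three measured steps bears directly on such a change, since each of them exchanges the whole group on the carbonyl carbon rather than inverting a single stereocentre. The measured steps therefore only set the frame: the acyl group is where the large movements come from, and compound 4 keeps the same acyl group as compound 3. He expects the step of a number 20 percentage points lower from compound 3 to compound 4 (beyond the scatter) to be a modest decrease, possibly not beyond the scatter, given that the data hold no stereo comparison at all. His estimate for compound 4 in this assay is 100%, with a range from 60% to 130%.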

Compound 4, largest response reached (Emax), in percent of the reference or control that the assay uses: 130%
The estimate for compound 4 lay 30 percentage points below the measured number, and the stated range covers the measured number.
By their numbers in this assay, from the lowest: compound 1; then compound 2; then compounds 3 and 4 (each within the scatter of the next).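

In this assay, among the compounds shown here, inverting one stereocentre at a saturated ring carbon of the 2-fluorocyclopropyl group gives a number 10 percentage points higher from compound 3 to compound 4 (within the scatter), the first stereo comparison, and this inversion does not separate the two compounds on this read-out. The large advantage of the 2-fluorocyclopropyl group over the other acyl groups also holds for the inverted form, with a number 50 percentage points higher from compound 2 to compound 4 (beyond the scatter) and a number 85 percentage points higher from compound 1 to compound 4 (beyond the scatter), so at this position the change of acyl group moves the maximal response far more than this single inversion does. One caution applies to reading the inversion as a clean comparison of two defined forms: the fact that one of compounds 3 and 4 is drawn with a defined configuration and the other without, at the place where they differ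

The compounds shown leave open how a plain cyclopropyl or a 2,2-difluorocyclopropyl group on the carbonyl carbon would compare with compound 3 and compound 4, and so whether the single fluorine matters for the high maximal response. They also leave open whether inverting the other stereocentre of the 2-fluorocyclopropyl group would have as little consequence in this assay as the inversion seen here.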